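From 4-methoxyphenyl to 3-fluorophenyl in compound 4

A few compounds are considered here, and "the series" means these few. Any claim that something is new, unique, unknown or untested is made for them only; others in the source may bear on it.

Measured so far in an ADME assay on MT4 cells (Homo sapiens) for cytotoxicity, read by MTT assay, with a stated time of 4 days (on this read-out lower numbers stand for higher toxicity in this test and higher numbers for lower toxicity in this test), for three compounds
Compound 1 `CC(=O)Nc1ccc2oc(-c3cccc(F)c3)cc(=O)c2c1` gives 240000 nM in this test
Compound 2 `COc1ccccc1-c1oc2ccc(NC(C)=O)cc2c(=O)c1OC` gives 154000 nM in this test
Compound 3 `COc1ccc(-c2oc3ccc(NC(C)=O)cc3c(=O)c2OC)cc1` gives 369000 nM in this test

Among the measured compounds shown here, the values of compound 3 and compound 1 lie within the scatter of each other, and the only measured step is a 2.4-fold higher number from compound 2 to compound 3 (0.38 log units; beyond the scatter) in size and direction. Compound 4 `COc1c(-c2cccc(F)c2)oc2ccc(NC(C)=O)cc2c1=O` carries 3-fluorophenyl in place of 4-methoxyphenyl on an aromatic carbon next to the ring oxygen, a difference counted as 3-fluorophenyl in place of 4-methoxyphenyl on an aromatic carbon in full. The measured step changed the group on that same carbon. For the measured compounds named here, compound 1 also carries 3-fluorophenyl and gives 240000 nM on a core without that methoxy group, but no measured step links it to compound 4. With only these data, a small move towards a lower number is expected, and none beyond the scatter. The estimated move is a 1.4-fold lower number from compound 3 to compound 4 (0.15 log units; within the scatter) and stays within that scatter. Compound 4 is estimated at 260000 nM with an expected range from 130000 nM to 480000 nM once it is tested.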

Compound 4, half-maximal cytotoxic concentration: 210000 nM
Compound 4: the middle estimate sits 1.2-fold (0.09 log units) above what was measured, within the range that was stated.
By their numbers in this assay, from the lowest: compounds 2, 4, 1 and 3 (each within the scatter of the next, the first and the last beyond it).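

In this assay, 3-fluorophenyl on the aromatic carbon next to the ring oxygen gives a 1.8-fold lower number from compound 3 to compound 4 (0.24 log units; within the scatter) and a 1.4-fold higher number from compound 2 to compound 4 (0.13 log units; within the scatter), so this group shows no step beyond the scatter from either methoxyphenyl group, unlike the earlier 2.4-fold higher number from compound 2 to compound 3 (0.38 log units; beyond the scatter). Among the compounds shown here, the result also gives the first one-place reading of the methoxy group on the core, with 3-fluorophenyl held constant: a 1.1-fold lower number from compound 1 to compound 4 (0.06 log units; within the scatter), again within the scatter. No supporting evidence bears on these steps, and they give no explanation for them.

On these data alone, the methoxy comparison rests on the 3-fluorophenyl pair alone, so its outcome with either methoxyphenyl group remains open. As far as these compounds go, it also remains open how this read-out would respond to an amine or a carboxylic acid on the phenyl ring, or to a longer chain in place of the acetyl group.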